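Cyclohexylmethyl replaces the acyl group on the ring nitrogen

This account rests on a few compounds, and the source may have more. Where it says the series, first, only, none or still open, it means among the compounds named here.

Compound 1 `O=C(CC1CCCCC1)N1CCN(c2nc(=O)c3cc(C(F)(F)F)cc([N+](=O)[O-])c3s2)CC1` and compound 2 `CSCC(=O)N1CCN(c2nc(=O)c3cc(C(F)(F)F)cc([N+](=O)[O-])c3s2)CC1` share a core and differ in one side chain. In an ADME assay on Vero cells (Chlorocebus sabaeus) for cytotoxicity, read by MTT assay, with a stated time of 72 h (on this read-out lower numbers stand for higher toxicity in this test and higher numbers for lower toxicity in this test), compound 1 gives > 125000 nM, which is a limit of the assay. Compound 2 gives > 125000 nM, which is also a limit, so it has no number of its own. Among the compounds with values here, the only measured step, a step that the two limits leave unreadable from compound 1 to compound 2, therefore offers no size to carry forward. Compound 3 `O=c1nc(N2CCN(CC3CCCCC3)CC2)sc2c([N+](=O)[O-])cc(C(F)(F)F)cc12` brings a different change: cyclohexylmethyl in place of ((methylsulfanyl)methyl)carbonyl on an amine nitrogen in a ring, with cyclohexylmethyl in place of ((methylsulfanyl)methyl)carbonyl on an amine nitrogen in a ring. Within the data shown here, no measured step covers this replacement. Because of the limit of > 125000 nM in this assay, at which 2 of the 2 values shown sit, only a step towards higher toxicity could be read in this assay. A moderate step of that kind is expected, an at least 1.7-fold lower number from compound 2 to compound 3 (0.25 log units; that floor lies within the scatter). The estimate for compound 3 is 70000 nM, with an expected range of 20000 nM to 125000 nM.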

Compound 3, half-maximal cytotoxic concentration: > 125000 nM
Compound 3: no number, only a limit; the forecaster's own chance of this, stated with the estimate: 45%; middle value at least 1.7-fold (0.25 log units) from the limit.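

In this assay compound 3 gives > 125000 nM as a limit of the assay. Within the data shown here, no step among compound 1, compound 2 and compound 3 can be read, because all three stop at the same limit: the limit of > 125000 nM in this assay, at which 3 of the 3 values shown sit. The compounds shown leave open whether these groups on the ring nitrogen differ at all in this assay and, if they do, in which direction.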